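Shortening the chain on compound 3: pentyl to propyl

The compounds below may be only part of what the source reports. "The series", "measured", "known", "first", "only" and "open" are said of these compounds alone.

Three compounds share one core and differ only in the group on the outer aromatic ring. Compound 1 `CC(C)(C)c1ccc(Nc2ccc3c(c2)C(=O)N(C2CCC(=O)NC2=O)C3=O)cc1` carries a tert-butyl group, and in an assay on FRT-Jurkat cells for inhibition of nuclear factor NF-kappa-B complex (Homo sapiens), read by flow cytometry, with a stated time of 24 h, tested at 10 uM (a higher number here means more inhibition at the concentration tested (going by the name of the read-out), a lower number less inhibition), compound 1 gives 17%. Compound 2 `CCOC(=O)c1ccc(Nc2ccc3c(c2)C(=O)N(C2CCC(=O)NC2=O)C3=O)cc1` carries an ethoxycarbonyl group, and in this assay compound 2 gives 5%. Compound 3 `CCCCCc1ccc(Nc2ccc3c(c2)C(=O)N(C2CCC(=O)NC2=O)C3=O)cc1` carries a pentyl chain, and in this assay compound 3 gives 12%. Compound 3 stands second highest of the three numbers; its gap to compound 1 and its gap to compound 2 are both within the scatter, so no order among these three can be read with confidence.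

Compound 4 `CCCc1ccc(Nc2ccc3c(c2)C(=O)N(C2CCC(=O)NC2=O)C3=O)cc1` is the next compound. Its difference from compound 3 is hydrogen in place of ethyl on a saturated chain carbon, three bonds along the chain from an aromatic carbon. The pentyl chain of compound 3 is a propyl chain in compound 4.

For the measured compounds named here, no measured step changes the length of such a chain. The step of a number 5 percentage points lower from compound 1 to compound 3 (within the scatter) and the step of a number 7 percentage points higher from compound 2 to compound 3 (within the scatter) only show that swapping the whole group out for pentyl moved the number little. The expected step is therefore none beyond the scatter, so for compound 4 a step of a number 2 percentage points lower from compound 3 to compound 4 (within the scatter) in this assay is estimated. The estimate for compound 4 in this assay is 10%, expected to fall between 0% and 22%.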

Compound 4, a percentage reported as inhibition, at one concentration (the size of the read-out at that concentration, not a potency): 10%
Beside the measured number, compound 4's estimate shows no gap at the digits printed; measured number inside the range.
By their numbers in this assay, from the lowest: compounds 2, 4, 3 and 1 (each within the scatter of the next, the first and the last beyond it).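

Shortening the pentyl chain to a propyl chain gives a number 2 percentage points lower from compound 3 to compound 4 (within the scatter) in this assay, the first direct look at chain length at this position, and across this one change the two numbers cannot be told apart. Compound 4 also cannot be separated from either of the other two compounds, with a number 5 percentage points higher from compound 2 to compound 4 (within the scatter) and a number 7 percentage points lower from compound 1 to compound 4 (within the scatter), even though the step between those two compounds, a number 12 percentage points lower from compound 1 to compound 2 (beyond the scatter), is the one gap in this set that lies beyond the scatter. Nothing available here explains why the numbers fall where they do.

The compounds shown leave open whether a butyl chain, a chain longer than pentyl or a shorter methyl group on the aromatic carbon would take the number beyond the scatter. They also leave open what an amine or a carboxylic acid in place of the chain would do, and, with a single tested concentration, how the potency of these compounds compares.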